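Swapping 1H-1,2,4-triazol-3-yl for 1,3-thiazol-2-yl on an amide-type nitrogen

The compounds below may be only part of what the source reports. "The series", "measured", "known", "first", "only" and "open" are said of these compounds alone.

Measured so far in a functional assay on cells (Mast cell, Rattus norvegicus) for inhibition, with a stated time of 15 min; a lower number here means that less compound is needed, a higher number that more compound is needed for the effect:
- compound 1 `O=C(O)CCCNC(=O)c1cc(=O)c2ccccc2o1`: > 18 ug/mL (a limit)
- compound 2 `O=C(Nc1nc[nH]n1)c1cc(=O)c2ccccc2o1`: 5 ug/mL

Among the measured compounds shown here, compound 2, at 5 ug/mL, holds the only actual number in this assay. Compound 1 reached only a limit, > 18 ug/mL.

The next compound to be tested is compound 3 `O=C(Nc1nccs1)c1cc(=O)c2ccccc2o1`, which carries 1,3-thiazol-2-yl in place of 1H-1,2,4-triazol-3-yl on an amide-type nitrogen. The shared core stays as it is.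

Just one measured step bears on this nitrogen: an at least 3.6-fold lower number from compound 1 to compound 2 (0.55 log units; beyond the scatter). That step brought in the 1H-1,2,4-triazol-3-yl group, but it started from 3-carboxypropyl, so it does not measure the present swap directly. Its size is also known only from one side. It gives a weak hint that the number may rise when 1H-1,2,4-triazol-3-yl leaves, and the direction remains uncertain. The expected change is a 3.0-fold higher number from compound 2 to compound 3 (0.48 log units; beyond the scatter), with a result reported only as a limit also possible. For compound 3 the estimate is 15 ug/mL, with an expected range from 4 ug/mL to 60 ug/mL.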

Compound 3, concentration for half-maximal effect: > 18 ug/mL
Compound 3: no number, only a limit (the forecaster's own chance of this, stated with the estimate: 35%); middle value at least 1.2-fold (0.07 log units) away from the limit.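

In this assay, among the compounds shown here, replacing 1H-1,2,4-triazol-3-yl with 1,3-thiazol-2-yl on the amide-type nitrogen gives an at least 3.6-fold higher number from compound 2 to compound 3 (0.55 log units; beyond the scatter), which is the first direct measure of a change between two five-membered aromatic rings at this position. The earlier step began from the open 3-carboxypropyl chain, whereas this one shows that a five-membered aromatic ring on this nitrogen does not by itself preserve the result of compound 2, since compound 3 carries such a ring with the same number of heavy atoms and ends at a limit. The step between compound 1 and compound 3 cannot be read, and compound 2 alone keeps an actual number: the limit of > 18 ug/mL in this assay, at which 2 of the 3 values shown sit.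

The two rings differ in their hetero atoms and in the hydrogen-bond donor that only 1H-1,2,4-triazol-3-yl carries, so these compounds cannot separate the sulfur for nitrogen exchange from the loss of that donor. On these data alone, whether a 1H-imidazol-2-yl or 1H-tetrazol-5-yl ring on this nitrogen would give an actual number in this assay stays open, and the full size of the step to compound 3 is known from one side only.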